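From Fluoro to Methyl at a Weak Compound

This account rests on a few compounds, and the source may have more. Where it says the series, first, only, none or still open, it means among the compounds named here.

In a functional assay on U-87MG ATCC cells for inhibition, with U-87 MG (Homo sapiens) as the target, read by MTT assay, with a stated time of 72 h (on this read-out higher numbers stand for weaker inhibition and lower numbers for stronger inhibition), compound 1 (`Oc1c(C(Nc2ccccn2)c2ccccc2F)ccc2cccnc12`) gives > 10000 nM as a limit of the assay and not a number. Compound 2 (`COc1ccc(C(Nc2cc(C)ccn2)c2ccc3cccnc3c2O)cc1O`) gives > 10000 nM as the same kind of limit. Among the measured compounds shown here, compound 3 (`Cc1ccnc(NC(c2ccccc2F)c2ccc3cccnc3c2O)c1`) reads 13100 nM and is the only one with an actual number. Compound 4 (`Cc1ccnc(NC(c2ccccc2C)c2ccc3cccnc3c2O)c1`) carries methyl in place of fluoro on an aromatic carbon, ortho to a large group (methyl in place of fluoro on an aromatic carbon). The measured steps are a step that the limit leaves unreadable from compound 1 to compound 3 and a step that the limit leaves unreadable from compound 2 to compound 3 and neither gives a size. Resting on compound 3 at 13100 nM alone, the expectation is a 1.1-fold lower number from compound 3 to compound 4 (0.04 log units; within the scatter) that stays within the scatter, with no direction favoured. Compound 4 is expected at 12000 nM with an estimated range from 5500 nM to 28000 nM in this assay and may report only as a limit.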

Compound 4, half-maximal inhibitory concentration: > 10000 nM
Compound 4 gave a limit, no number; the forecaster's own chance of this, stated with the estimate: 45%; the middle value is on the limit's open side.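

Compound 4 gives > 10000 nM, a limit and not a number, so neither step to compound 4, from compound 3 or from compound 2, can be read. The compounds shown leave open how methyl and fluoro compare at this position and how these compounds rank: the limit of > 10000 nM in this assay, at which 3 of the 4 values shown sit.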